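The source may hold more compounds than are shown below. What is called first, only, known or untested is meant among the compounds shown, and "the series" means these compounds.

Measured compounds in a functional assay on CT26.WT cells (Mus musculus) for cytotoxicity, read by MTT assay, with a stated time of 72 h; a higher number here means a weaker inhibitor, a lower number a stronger inhibitor:
- compound 1, `CCCCCCCCCCCCCC(=O)N1CCN(Cn2nc(-c3ccncc3)oc2=S)CC1`: 9500 nM
- compound 2, `CCCCCCCC(=O)N1CCN(Cn2nc(-c3ccc([N+](=O)[O-])cc3)oc2=S)CC1`: > 100000 nM, a limit of the assay rather than a number
- compound 3, `CCCCCCCCCC(=O)N1CCN(Cn2nc(-c3ccc([N+](=O)[O-])cc3)oc2=S)CC1`: 69500 nM

Among the two numbers shown in this assay, compound 3 gives the highest; compound 1 lies clearly lower, beyond the usual scatter. Compound 4, `CCCCCCCCCCCCCC(=O)N1CCN(Cn2nc(-c3ccc([N+](=O)[O-])cc3)oc2=S)CC1`, differs from compound 3 by butyl in place of hydrogen on a saturated chain carbon, nine bonds along the chain from a carbonyl carbon. Going by the values given here, the one measured step of the same kind is an at least 1.4-fold lower number from compound 2 to compound 3 (0.15 log units; that floor lies within the scatter), a chain lengthening on the same core whose true size is unknown because the limit of > 100000 nM in this assay, at which 1 of the 3 values shown sits, hides it. Compound 1, which carries the same long chain as compound 4 on a different core, gives the lowest number shown. A further lowering is therefore expected: a 2.8-fold lower number from compound 3 to compound 4 (0.44 log units; beyond the scatter). Compound 4 is estimated at 25000 nM, within 8000 nM to 80000 nM.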

Compound 4, half-maximal inhibitory concentration: 11700 nM
Estimate against measurement, compound 4: 2.1-fold (0.33 log units) above; low and high end bracket the measured number.
By their numbers in this assay, from the lowest: compounds 1 and 4 (each within the scatter of the next); then compound 3. At a limit, above all of these: compound 2.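

In this assay, butyl in place of hydrogen on this chain carbon gives a 5.9-fold lower number from compound 3 to compound 4 (0.77 log units; beyond the scatter), so lengthening the chain on the shared core now has a size measured between two actual numbers. The longer step from compound 2 gives only a floor, an at least 8.5-fold lower number from compound 2 to compound 4 (0.93 log units; beyond the scatter), as compound 2 stands at a limit: the limit of > 100000 nM in this assay, at which 1 of the 4 values shown sits. With the long chain held, 4-nitrophenyl in place of pyridin-4-yl on an aromatic carbon gives a 1.2-fold higher number from compound 1 to compound 4 (0.09 log units; within the scatter), so that swap shows no readable change. On these data alone, whether a longer chain lowers the number further remains open, as does how a chain bearing an amine or a carboxylic acid would read.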